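A second methoxy on the aryl ring of compound 1

This account rests on a few compounds, and the source may have more. Where it says the series, first, only, none or still open, it means among the compounds named here.

For the measured compounds named here, compound 1 `COc1ccc(-c2cc(/C=C/C(=O)c3ccc(N)cc3)[nH]n2)cc1` is one of two compounds measured in a functional assay on SN12C cells (Homo sapiens) for inhibition, read by sulforhodamine B assay, with a stated time of 48 h; a lower number here means a stronger inhibitor of growth, a higher number a weaker inhibitor of growth. In this assay compound 1 gives 1890 nM. Going by the values given here, the only other measured compound is compound 2 `COc1ccc(C(=O)/C=C/c2cc(-c3cc(OC)c(OC)c(OC)c3)n[nH]2)cc1OC`, which in this assay gives 1540 nM; the two numbers lie within the usual scatter of each other, so nothing separates them.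

Compound 3 `COc1ccc(-c2cc(/C=C/C(=O)c3ccc(N)cc3)[nH]n2)cc1OC` is not yet measured. It differs from compound 1 in one place: methoxy in place of hydrogen on an aromatic carbon, ortho to a methoxy group and meta to a large group. Among the compounds with values here, no step between measured compounds tracks this change, so the expectation can only be modest. Since compound 2, which also carries two adjacent methoxy groups, gives 1540 nM, a step from compound 1 to compound 3 of a 1.3-fold lower number from compound 1 to compound 3 (0.10 log units; within the scatter) is expected, not beyond the scatter in either direction. Compound 3 is therefore estimated at 1500 nM, with a range from 600 nM to 3800 nM.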

Compound 3, concentration for 50% growth inhibition: 3530 nM
Compound 3: the middle estimate sits 2.4-fold (0.37 log units) below what was measured, and the stated range covers the measured number.
By their numbers in this assay, from the lowest: compounds 2, 1 and 3 (each within the scatter of the next, the first and the last beyond it).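

Methoxy in place of hydrogen on an aromatic carbon, ortho to a methoxy group and meta to a large group, now has a measured step of its own: in this assay it gives a 1.9-fold higher number from compound 1 to compound 3 (0.27 log units; within the scatter) and so stays inside the usual variation of the read-out. On the core of compound 1, this change therefore shows neither a gain nor a loss, and the pair gives no ground for saying that the added methoxy helps or harms growth inhibition. No measurement is available that would explain this step.

The compounds shown leave open whether another group at this position, such as a hydroxyl, a fluorine or an ethoxy, would give a number beyond the scatter. They also leave open whether replacing the amine shared by compound 1 and compound 3 with an acetamide would shift the number.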